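Shortening an unsaturated amide chain where nothing yet registers

The source may report more compounds than this note shows. Statements on the series, on what has been measured and on what is new or still open speak of the compounds shown alone.

Compound 1 `C/C=C/C(=O)Nc1ccc(Cn2nc(-c3ccc(Oc4ccccc4)cc3)cc2CO)cc1` carries a ((prop-1-en-1-yl)carbonyl)amino group. In a functional assay on JeKo-1 cells (Homo sapiens) for inhibition, read by luminescence and CellTiter-Glo, with a stated time of 72 h (a lower number here means a stronger inhibitor, a higher number a weaker inhibitor), compound 1 gives > 60000 nM, which is a limit of the assay and not a number. Compound 3 `C/C=C/C(=O)N1CCCC(n2nc(-c3ccc(Oc4ccccc4)cc3)cc2C(=O)O)C1` is built on another core; the difference between the two cores is not broken down here. In this assay compound 3 gives > 60000 nM, again only a limit. Compound 2 `C=CC(=O)N1CCCC(n2nc(-c3ccc(Oc4ccccc4)cc3)cc2C(=O)O)C1` differs from compound 3 by vinyl in place of prop-1-en-1-yl on a carbonyl carbon. Compound 2 likewise gives only a limit, > 60000 nM. The step that the two limits leave unreadable from compound 3 to compound 2 therefore has no readable size because of the limit of > 60000 nM in this assay, at which 3 of the 3 values shown sit.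

Compound 4 `C=CC(=O)Nc1ccc(Cn2nc(-c3ccc(Oc4ccccc4)cc3)cc2CO)cc1` has not been measured. It differs from compound 1 by vinyl in place of prop-1-en-1-yl on a carbonyl carbon. This is the same kind of change as from compound 3 to compound 2, though not the same: there the carbonyl carbon sits on an amide-type nitrogen in a ring, here on an amide-type nitrogen. With the measured step unreadable, the expectation rests on compound 1 sitting at its limit > 60000 nM. The step from compound 1 to compound 4 is estimated as a step that the limit leaves unreadable from compound 1 to compound 4. Compound 4 is expected to give about 80000 nM, between 20000 nM and 300000 nM, most probably reported once more as a limit.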

Compound 4, half-maximal inhibitory concentration: 8000 nM
The estimate for compound 4 lay 10-fold (1.00 log units) above the measured number, and the stated range ends above it.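

In this assay, putting vinyl in place of prop-1-en-1-yl on the carbonyl carbon gives an at least 7.5-fold lower number from compound 1 to compound 4 (0.87 log units; beyond the scatter), so on the core of compound 1 this small change is enough to bring the result inside the range of the assay. On the other core the same kind of change cannot be read, because compound 3 and compound 2 both stay at a limit: the limit of > 60000 nM in this assay, at which 3 of the 4 values shown sit. The gain is therefore shown on one core only and is not shown to carry over, and compound 2, which carries vinyl on the other core, gives > 60000 nM, a limit of the assay and not a number.

On these data alone, whether vinyl would give a readable number on any core other than that of compound 4 stays open. Also open, as far as these compounds go, is how a longer chain on the carbonyl carbon, or an amine carried on the vinyl group, would read in this assay.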